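Amine-substituent replacement on the shared core

The source may report more compounds than this note shows. Statements on the series, on what has been measured and on what is new or still open speak of the compounds shown alone.

Measured compounds:
compound 1 `COCCNC(=O)CNc1ncc2c(Br)nn(-c3ccc4ncccc4c3)c2n1` – "nd" (no result reported)
compound 2 `COCCNC(=O)[C@H]1C[C@H](Nc2ncc3c(Br)nn(-c4ccc5ncccc5c4)c3n2)C1` – 86 nM

In an assay on SK-OV-3 cells for inhibition of eIF-2-alpha kinase GCN2 (Homo sapiens) (on this read-out lower numbers stand for stronger inhibition and higher numbers for weaker inhibition), compound 1 gives "nd" (no result reported), so it stands with no single number to anchor a step. In this assay compound 2 gives 86 nM. For the measured compounds named here, no step between measured compounds is known. Compound 3 `Brc1nn(-c2ccc3ncccc3c2)c2nc(N[C@@H]3CC[C@@H](c4ncc[nH]4)C3)ncc12` differs from compound 1 by a group of 10 heavy atoms (8 carbon, 2 nitrogen; one five-membered non-aromatic ring of carbon only, one five-membered aromatic ring with 2 hetero atoms) in place of a group of 8 heavy atoms (5 carbon, 1 nitrogen, 2 oxygen; no ring), on a nitrogen on an aromatic ring. In this assay the result for compound 3 is expected to fall near that of compound 2, with no direction beyond the scatter claimed. Compound 3 is estimated at 60 nM, within 10 nM to 350 nM.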

Compound 3, half-maximal inhibitory concentration: 545 nM
Compound 3: middle estimate off by 9.1-fold (0.96 log units), on the low side; measured number above the stated range.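

For the compounds shown here, compound 1 at "nd" (no result reported) and compound 3 at 545 nM in this assay give no step that can be read. As far as these compounds go, how replacing the ((2-methoxyethyl)carbamoyl)methyl group changes the read-out stays open, and no supporting data bear on the result.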